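The compounds below may be only part of what the source reports. "The series", "measured", "known", "first", "only" and "open" are said of these compounds alone.

Measured so far:
- compound 1 `COc1cccc2c1ccn2S(=O)(=O)c1ccccc1`: 262 nM
- compound 2 `COc1ccc2c(ccn2S(=O)(=O)c2ccccc2)c1`: 127 nM
- compound 3 `O=S(=O)(c1ccccc1)n1cc(N2CCCCC2)c2ccccc21`: 219 nM

All three numbers come from an assay on isolated protein for displacement of a labelled ligand from 5-hydroxytryptamine receptor 6 (Homo sapiens), read by scintillation counting, with a stated time of 1 h; a lower number here means a stronger inhibitor, a higher number a weaker inhibitor. Compound 1 has the highest of the three, with compound 3 within the scatter of it and compound 2 beyond it. No two of these compounds differ in a single place, so no single step has been isolated.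

Compound 4 `CC(=O)N1CCN(c2cccc3c2ccn3S(=O)(=O)c2ccccc2)CC1` is the next entry and remains unmeasured in this assay. It differs from compound 1 by 4-acetylpiperazin-1-yl in place of methoxy on an aromatic carbon. Going by the values given here, no measured pair shows what such an exchange does. The working expectation is a step from compound 1 of a 1.6-fold lower number from compound 1 to compound 4 (0.21 log units; within the scatter), a size that could still fall within the scatter, and compound 4 is estimated at 160 nM with a range of 40 nM to 650 nM.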

Compound 4, inhibition constant: 714 nM
Beside the measured number, compound 4's estimate is 4.5-fold (0.65 log units) below it, and the stated range ends below it.
By their numbers in this assay, from the lowest: compounds 2, 3 and 1 (each within the scatter of the next, the first and the last beyond it); then compound 4.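

Going by these compounds alone, at this aromatic carbon, ortho to a fused ring, this assay now gives the first single-place step: 4-acetylpiperazin-1-yl in place of methoxy produces a 2.7-fold higher number from compound 1 to compound 4 (0.44 log units; beyond the scatter) and is a modest loss beyond the scatter. Binding is still measurable with this much larger group in place. No supporting data bear on the reason for this step.

From the compounds shown here alone, it remains open whether the loss follows from the acetyl group or from the piperazine ring itself. An unsubstituted piperazine or a morpholine at this carbon would separate the two.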